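This account rests on a few compounds, and the source may have more. Where it says the series, first, only, none or still open, it means among the compounds named here.

Compound 1: `CCOC(=O)C1=C(C)NC(C)=C(C(=O)OCC)C1c1c(-c2ccccc2F)nc2sccn12` — 980 nM
Compound 2: `CCOC(=O)C1=C(C)NC(C)=C(C(=O)OCC)C1c1c(-c2ccc(F)c(F)c2)nc2sccn12` — 100 nM

Among the compounds with values here, in an ADME assay on Right cardiac atrium (Cavia porcellus) (a higher number here means that more compound is needed for the effect, a lower number that less compound is needed), compound 2 gives the lower of the two numbers recorded so far, and its only neighbour is compound 1, separated by the step of a 9.8-fold lower number from compound 1 to compound 2 (0.99 log units; beyond the scatter), which came with the change from 2-fluorophenyl to 3,4-difluorophenyl on an aromatic carbon. Compound 3 is `CCOC(=O)C1=C(C)NC(C)=C(C(=O)OCC)C1c1c(-c2cc(F)c(F)cc2F)nc2sccn12`; it differs from compound 2 by fluoro in place of hydrogen on an aromatic carbon, so that the difference read one bond further out is 3,4-difluorophenyl to 2,4,5-trifluorophenyl. Within the data shown here, only the step from compound 1 to compound 2 bears on this change, and it concerns a different rearrangement of fluoro groups rather than the addition of one, so it is a weak guide. A further fluoro is a small change, and for compound 3 a step of about a 1.3-fold lower number from compound 2 to compound 3 (0.10 log units; within the scatter) in this assay is expected, within or only slightly beyond the scatter. Compound 3 is therefore estimated at 80 nM, with a range from 25 nM to 300 nM.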

Compound 3, half-maximal effective concentration: 1240 nM
Compound 3: middle estimate off by 16-fold (1.19 log units), on the low side; the measured number lies above the stated range.
By their numbers in this assay, from the lowest: compound 2; then compounds 1 and 3 (each within the scatter of the next).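

In this assay a single fluoro on the aromatic carbon ortho to a large group proves to be a large change, not a minor one (a 12-fold higher number from compound 2 to compound 3 (1.09 log units; beyond the scatter)). With that fluoro present, the two further fluoro groups of 2,4,5-trifluorophenyl leave the number within the scatter (a 1.3-fold higher number from compound 1 to compound 3 (0.10 log units; within the scatter)), so among these three compounds the lowest number belongs to compound 2, the only one without a fluoro at that place. No measurement at hand gives a reason for this.

The compounds shown leave open whether a chloro, methyl or methoxy group at the same place would raise the number as fluoro does. They also leave open how the plain phenyl ring compares with these fluorinated rings.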